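The compounds below may be only part of what the source reports. "The series", "measured", "known", "first", "only" and "open" are said of these compounds alone.

Compound 1 `O=c1cc(/C=C/c2ccc(OC(F)(F)F)cc2)oc2ccccc12` gives 15600 nM.
Compound 2 `COc1cc(/C=C/c2cc(=O)c3c(OC)cc(OC)cc3o2)cc(OC)c1` gives 15600 nM.
Compound 3 `COc1cc(OC)c2c(=O)cc(/C=C/c3ccc(Br)cc3)oc2c1` gives > 40000 nM.

All three values come from a functional assay on A549 cells (Homo sapiens) for antiproliferative activity, read by MTT assay, with a stated time of 12 h; on this read-out lower numbers stand for stronger inhibition and higher numbers for weaker inhibition. Compound 1 and compound 2 sit within the usual scatter of each other. Compound 3 stands at the limit of > 40000 nM in this assay, at which 1 of the 3 values shown sits, so its entry is a limit of the assay and not a number. Compound 4 `COc1cc(OC)c2c(=O)cc(/C=C/c3ccccc3)oc2c1` has not yet been measured in this assay. Compared with compound 3 it carries hydrogen in place of bromo on an aromatic carbon. For the measured compounds named here, no measured pair shows this change, so the size of the step is unknown from the data; the expectation is a move in this assay of no more than the scatter, in either direction. Compound 4 is therefore estimated at 35000 nM, with a range from 12000 nM to 90000 nM. The expected step is an at least 1.1-fold lower number from compound 3 to compound 4 (0.05 log units; that floor lies within the scatter).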

Compound 4, half-maximal inhibitory concentration: 21500 nM
The estimate for compound 4 lay 1.6-fold (0.21 log units) above the measured number, within the range that was stated.
By their numbers in this assay, from the lowest: compounds 1, 2 and 4 (each within the scatter of the next). At a limit, above all of these: compound 3.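

Replacing bromo with hydrogen on the aromatic carbon, 4-bromophenyl to phenyl, gives in this assay an at least 1.8-fold lower number from compound 3 to compound 4 (0.26 log units; that floor lies within the scatter). For the compounds shown here, this is the first view of this position, and it shows that the phenyl compound gives a number, though the step is only a floor and its full size cannot be read. Compound 3 stands at a limit of the assay and not at a number: the limit of > 40000 nM in this assay, at which 1 of the 4 values shown sits.

The compounds shown leave open how an amine or a carboxylic acid at this position would read. They also leave open whether the same change would give a similar step on another core.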